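A few compounds are considered here, and "the series" means these few. Any claim that something is new, unique, unknown or untested is made for them only; others in the source may bear on it.

Compound 2 `COc1ccc(/C=N/NC(=O)Nc2ccc(Oc3ccnc(-c4nncn4CCN(C)C)c3)c(F)c2)cc1O` carries a 3-hydroxy-4-methoxyphenyl on the carbon with a double bond to nitrogen. In a functional assay on U-87MG ATCC cells (Homo sapiens) for cytotoxicity, read by MTT assay, with a stated time of 72 h (on this read-out lower numbers stand for stronger inhibition and higher numbers for weaker inhibition), compound 2 is reported only as a limit of the assay, > 100000 nM. Compound 1 `CN(C)CCn1cnnc1-c1cc(Oc2ccc(NC(=O)N/N=C/c3c(Cl)cccc3Cl)cc2F)ccn1`, the 2,6-dichlorophenyl counterpart, is likewise reported in this assay as a limit, > 100000 nM. The step that the two limits leave unreadable from compound 1 to compound 2 is accordingly of unknown size and direction. The whole of the evidence reduces to the limit of > 100000 nM in this assay, at which 2 of the 2 values shown sit, so no readable step exists among the measured compounds.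

Compound 3 `COc1cc(/C=N/NC(=O)Nc2ccc(Oc3ccnc(-c4nncn4CCN(C)C)c3)c(F)c2)ccc1O` differs from compound 2 by 4-hydroxy-3-methoxyphenyl in place of 3-hydroxy-4-methoxyphenyl on a carbon with a double bond to nitrogen. No measured step in this assay bears on this swap, and the single step shown is itself unreadable, so nothing in the data points to a gain or a loss. The step of a number no higher from compound 2 to compound 3 (the limit leaves the size open) is expected to stay within the scatter, with compound 3 most likely again reported only as a limit. The estimated value for compound 3 in this assay is 100000 nM, with a range from 40000 nM to 250000 nM.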

Compound 3, half-maximal inhibitory concentration: > 100000 nM
Compound 3: only a limit was reported (the forecaster's own chance of this, stated with the estimate: 85%); the middle value sits exactly at the limit.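

In this assay, among the compounds shown here, compound 3 gives > 100000 nM as a limit of the assay, so no step among compound 1, compound 2 and compound 3 can be read, in size or in direction. The compounds shown leave open whether any group on the carbon with a double bond to nitrogen brings a readable value in this assay at all.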